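Working notes: replacing the 3,4-dimethoxyphenyl group of compound 2

The compounds below may be only part of what the source reports. "The series", "measured", "known", "first", "only" and "open" are said of these compounds alone.

Measured in a functional assay, read by spectrophotometry, with a stated time of 5 min; a higher number here means a weaker inhibitor, a lower number a stronger inhibitor:
- compound 1 `CCOc1ccc(C=C(C(=O)/C=C/c2ccc(O)c(OC)c2)C(=O)/C=C/c2ccc(O)c(OC)c2)cc1OCC`: 10000 nM
- compound 2 `CCOc1cc(/C=C/C(=O)C(=Cc2ccc(OC)c(OC)c2)C(=O)/C=C/c2ccc(O)c(OCC)c2)ccc1O`: 11300 nM

Compound 2 gives 11300 nM and compound 1 gives 10000 nM. These values lie within the scatter of each other, so they show no order. Compound 3 `CCOc1cc(/C=C/C(=O)C(=Cc2ccc(O)cc2)C(=O)/C=C/c2ccc(O)c(OCC)c2)ccc1O` has not yet been measured. Its change from compound 2 is 4-hydroxyphenyl in place of 3,4-dimethoxyphenyl on a double-bonded chain carbon bound to a double-bonded chain carbon. Among the measured compounds shown here, no measured pair isolates this change, so the expectation has little to rest on. A small step toward a lower number is expected in this assay, perhaps none beyond the scatter. The expected move is a 1.4-fold lower number from compound 2 to compound 3 (0.15 log units; within the scatter). For compound 3 the estimated value is 8000 nM, with an expected range of 3000 nM to 20000 nM.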

Compound 3, half-maximal inhibitory concentration: 14800 nM
Compound 3: middle estimate off by 1.9-fold (0.27 log units), on the low side; low and high end bracket the measured number.
By their numbers in this assay, from the lowest: compounds 1, 2 and 3 (each within the scatter of the next).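

In this assay, among the compounds shown here, the first single change at this place, 4-hydroxyphenyl in place of 3,4-dimethoxyphenyl on a double-bonded chain carbon bound to a double-bonded chain carbon, gives a step that stays within the scatter (a 1.3-fold higher number from compound 2 to compound 3 (0.12 log units; within the scatter)). The entering group has fewer heavy atoms and carries a hydrogen-bond donor that the leaving group lacks, yet this exchange produces no readable change in the number. No supporting measurement bears on the reason for this result. 

Still open, on these data alone, is whether any group at this place can move the number beyond the scatter, for example an amine, a carboxylic acid or a longer alkoxy chain. A 4-methoxyphenyl group would also separate the effect of the hydroxyl from that of the two methoxy groups, and the same exchange could behave differently on another core.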